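This account rests on a few compounds, and the source may have more. Where it says the series, first, only, none or still open, it means among the compounds named here.

Compound 1 `NC(=O)C(=O)NCCCCCC(=O)Nc1ccccc1` was tested in a functional assay on HCT-116 cells (Homo sapiens) for inhibition, read by colorimetric assay, with a stated time of 3 days; on this read-out higher numbers stand for weaker inhibition and lower numbers for stronger inhibition. There compound 1 gives > 100000 nM, which is a limit and not a number. Compound 2 `O=C(CCCCCNC(=O)c1ccc[nH]1)Nc1ccccc1` gives > 100000 nM, which is also a limit. The evidence so far is therefore (the limit of > 100000 nM in this assay, at which 2 of the 2 values shown sit). Among the measured compounds shown here, the one measured change, a step that the two limits leave unreadable from compound 1 to compound 2, has no size that can be read.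

Compound 3 `O=C(CCCCCCC(O)C(F)(F)F)Nc1ccccc1` differs from compound 1 by 3,3,3-trifluoro-2-hydroxypropyl in place of (carbamoylcarbonyl)amino on a saturated chain carbon, five bonds along the chain from a carbonyl carbon. In words, this is 3,3,3-trifluoro-2-hydroxypropyl in place of (carbamoylcarbonyl)amino on a saturated chain carbon, five bonds along the chain from a carbonyl carbon.

For the measured compounds named here, with a step that the two limits leave unreadable from compound 1 to compound 2 as the only guide, no gain or loss can be forecast, and another limit is the likeliest result. The expected change is none beyond the scatter: a number no higher from compound 1 to compound 3 (the limit leaves the size open). For compound 3 the estimated value in this assay is 100000 nM, with an expected range from 30000 nM to 300000 nM.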

Compound 3, half-maximal inhibitory concentration: > 40000 nM
Compound 3: only a limit was reported; the forecaster's own chance of this, stated with the estimate: 75%; the middle value lies beyond the limit too.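

In this assay compound 3 gives > 40000 nM, which is a limit and not a number. Compound 1 also has only a limit, so the step between compound 1 and compound 3 cannot be read. The compounds shown leave open which change, if any, would give a true number in this assay.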